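Amide variations on the hexafluoro-carbinol naphthylamine core

The compounds below may be only part of what the source reports. "The series", "measured", "known", "first", "only" and "open" are said of these compounds alone.

Measured so far:
- compound 1, `CC(C)C(=O)Nc1c(C(O)(C(F)(F)F)C(F)(F)F)ccc2ccccc12`: 6630 nM
- compound 2, `O=C(Nc1c(C(O)(C(F)(F)F)C(F)(F)F)ccc2ccccc12)C1CCC1`: 45 nM
- compound 3, `COCC(=O)Nc1c(C(O)(C(F)(F)F)C(F)(F)F)ccc2ccccc12`: 213 nM

All three were read in an assay on LtK cells with ATP-sensitive inward rectifier potassium channel 11 (Homo sapiens) as the target; on this read-out lower numbers stand for an effect already at smaller amounts and higher numbers for an effect only at larger amounts of compound. Compound 2 stands lowest of the three: compound 3 is nearest, with a 4.7-fold higher number from compound 2 to compound 3 (0.68 log units; beyond the scatter), and compound 1 is furthest, with a 150-fold lower number from compound 1 to compound 2 (2.17 log units; beyond the scatter) separating them.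

The next compound is compound 4, `O=C(Nc1c(C(O)(C(F)(F)F)C(F)(F)F)ccc2ccccc12)c1ccc(C(F)(F)F)cc1`. Against compound 2 the change is 4-(trifluoromethyl)phenyl in place of cyclobutyl on a carbonyl carbon.

Among the measured compounds shown here, no measured step brings an aromatic group onto this carbonyl carbon, so no pair speaks to the change directly. For the measured compounds named here, two steps touch the same position: the large one from isopropyl to cyclobutyl, a 150-fold lower number from compound 1 to compound 2 (2.17 log units; beyond the scatter), and the modest one from cyclobutyl to methoxymethyl, a 4.7-fold higher number from compound 2 to compound 3 (0.68 log units; beyond the scatter). Both show that this carbonyl substituent moves the read-out strongly in this assay, and that cyclobutyl is the best-placed group so far. Going by the values given here, with a much larger entering group and no aromatic precedent, a move away from the low number of compound 2 is expected; the size is open. The expected step is an 8.9-fold higher number from compound 2 to compound 4 (0.95 log units; beyond the scatter), a higher number for compound 4. Compound 4 is estimated at 400 nM, with a range from 60 nM to 3000 nM.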

Compound 4, half-maximal effective concentration: 160 nM
For compound 4 the middle estimate is 2.5-fold (0.40 log units) above the measured one, within the range that was stated.
By their numbers in this assay, from the lowest: compound 2; then compounds 4 and 3 (each within the scatter of the next); then compound 1.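

Notes on the carbonyl substituent: an aromatic group is now shown to be tolerated on this carbonyl carbon in this assay, since 4-(trifluoromethyl)phenyl in place of isopropyl gives a 41-fold lower number from compound 1 to compound 4 (1.62 log units; beyond the scatter) and so keeps most of the gain seen with cyclobutyl. Cyclobutyl still holds the lowest number, and a 3.6-fold higher number from compound 2 to compound 4 (0.55 log units; beyond the scatter) shows that the much larger ring costs only a modest step, far smaller than the gap that separates the isopropyl amide from the other three compounds. Against methoxymethyl the reading is a 1.3-fold lower number from compound 3 to compound 4 (0.12 log units; within the scatter) and the two compounds cannot be told apart, so two quite different groups now sit level at this place, while compound 1 alone stands far above the rest.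

Nothing at hand gives a reason for any of these steps. The compounds shown leave open what the trifluoromethyl adds compared with a plain phenyl, and how a cyclopropyl or cyclopentyl ring, or an amine on a longer chain, would read on this carbonyl carbon.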